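Compound 1 and a swap to a carbonyl group

The compounds below may be only part of what the source reports. "The series", "measured", "known", "first", "only" and "open" are said of these compounds alone.

Among the compounds with values here, in a functional assay on A549 cells (Homo sapiens) for antiproliferative activity, read by MTT assay, with a stated time of 24 h (a higher number here means a weaker inhibitor, a lower number a stronger inhibitor), compound 1 (`O=C(NNc1cccc(Cl)c1)c1cccc(NS(=O)(=O)c2cnc(O)nc2O)c1`) gives 6640 nM as the higher of the two true numbers so far. Compound 3 (`O=C(NNC(=O)c1ccccc1Cl)c1ccc(NS(=O)(=O)c2cnc(O)nc2O)cc1`) gives 1900 nM as a lower number, a gap beyond the usual scatter. Compound 2 (`O=C(NNc1ccc(F)cc1)c1ccccc1NS(=O)(=O)c1cnc(O)nc1O`) reads > 20000 nM as a limit of the assay, not a number. Compound 4 (`Cc1ccc(C(=O)NNC(=O)c2cccc(NS(=O)(=O)c3cnc(O)nc3O)c2)cc1`) has not been measured. Its difference from compound 1 is (4-methylphenyl)carbonyl in place of 3-chlorophenyl on an amine nitrogen with (4-methylphenyl)carbonyl in place of 3-chlorophenyl on an amine nitrogen. Within the data shown here, no measured step isolates this change, so only a modest move toward a lower number in this assay is expected, resting on compound 3 at 1900 nM with its own carbonyl on that nitrogen. The estimated change is a 1.7-fold lower number from compound 1 to compound 4 (0.24 log units; within the scatter) and may stay close to the scatter. Compound 4 is expected at 3800 nM (estimated range 1000 nM to 14000 nM).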

Compound 4, half-maximal inhibitory concentration: > 20000 nM
Compound 4: only a limit was reported; the forecaster's own chance of this, stated with the estimate: 8%; at least 5.2-fold (0.72 log units) between middle value and limit.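

In this assay, this position now has its first measured step, an at least 3.0-fold higher number from compound 1 to compound 4 (0.47 log units; beyond the scatter), so (4-methylphenyl)carbonyl on this amine nitrogen gives weaker activity than 3-chlorophenyl. Compound 4 reads as a limit of the assay and not a number, so the full size of this loss stays unknown: the limit of > 20000 nM in this assay, at which 2 of the 4 values shown sit.

The swap adds a carbonyl and changes the ring's substituent together, and the compounds shown do not separate the two. Also open, as far as these compounds go, is how a small acetyl group or a longer alkyl chain on this nitrogen would read.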